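The source may hold more compounds than are shown below. What is called first, only, known or untested is meant among the compounds shown, and "the series" means these compounds.

Measured so far in a functional assay on HL-60 cells (Homo sapiens) for antiproliferative activity, read by MTT assay; a higher number here means a weaker inhibitor, a lower number a stronger inhibitor:
- compound 1 `CCCC[C@@H]1O[C@H](COCc2ccccc2)[C@@H](OCc2ccccc2)[C@H](OCc2ccccc2)[C@H]1O`: "not active" (no number reported)
- compound 2 `CC(C)C[C@@H]1O[C@H](COCc2ccccc2)[C@@H](OCc2ccccc2)[C@H](OCc2ccccc2)[C@H]1O`: 8500 nM

Among the compounds with values here, compound 2 holds the only number, 8500 nM, while compound 1 was reported as "not active" (no number reported) and has no number to set beside it. Within the data shown here, no ranking by size is therefore possible, and no measured step is available as a guide.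

Compound 3 `O[C@H]1CO[C@H](COCc2ccccc2)[C@@H](OCc2ccccc2)[C@@H]1OCc1ccccc1` follows from compound 2 by a single change: hydrogen in place of isobutyl on a saturated ring carbon, next to the ring oxygen and next to the ring atom that bears a hydroxy group. The counted difference is hydrogen in place of isobutyl on a saturated ring carbon.

Among the measured compounds shown here, the data hold no example of this change, so the expectation is loose. It rests on what the values show: compound 2 gives a number of 8500 nM and compound 1 gives none, so a result without a number is a real possibility for compound 3. A moderate loss in this assay is expected, in the direction of weaker inhibition, and the estimated step is a 2.4-fold higher number from compound 2 to compound 3 (0.37 log units; beyond the scatter). For compound 3 the expected value is 20000 nM, with an estimated range of 7000 nM to 60000 nM.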

Compound 3, half-maximal inhibitory concentration: "not active" (no number reported)
Nothing numeric was reported for compound 3; the estimate stays without a comparison.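

In this assay compound 3 gives "not active" (no number reported) and compound 2 gives 8500 nM, so no step can be read between compound 2 and compound 3. No measured evidence bears on this result. The compounds shown leave open how much the isobutyl group contributes in this assay and whether any other group on that saturated ring carbon would give a number.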